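The compounds below may be only part of what the source reports. "The series", "measured", "known", "first", "only" and "open" are said of these compounds alone.

In a functional assay on NCI-H460 cells (Homo sapiens) for cytotoxicity, read by MTT assay, with a stated time of 68 h (a higher number here means a weaker inhibitor, a lower number a stronger inhibitor), compound 1 (`O=C(Nc1cccc(-c2ccc(-c3ccccc3)cc2)c1)C(Cl)Cl`) gives 10900 nM. Compound 2 (`CC(C)c1ccc(-c2cc(NC(=O)C(Cl)Cl)cc(-c3ccc(C(C)C)cc3)c2)cc1`) gives 24800 nM in this assay. Among the measured compounds shown here, of these two numbers, the one for compound 1 is the lower, and the gap between them lies beyond the usual scatter, which makes compound 1 the stronger inhibitor of the pair.

Compound 3 (`O=C(Nc1cccc(-c2ccc(F)cc2)c1)C(Cl)Cl`) has yet to be tested. It departs from compound 1 in one place: fluoro in place of phenyl on an aromatic carbon.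

For the measured compounds named here, no measured pair shows this change, so the data offer no direct guide to its size. The expectation starts from compound 1 at 10900 nM and from the loss of a whole aromatic ring, and with so few numbers it stays loose. A move towards weaker inhibition, probably beyond the scatter, is expected, and the estimated step in this assay is a 2.6-fold higher number from compound 1 to compound 3 (0.41 log units; beyond the scatter). For compound 3 the estimated value is 28000 nM, with an expected range from 10000 nM to 80000 nM.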

Compound 3, half-maximal inhibitory concentration: > 50000 nM
Compound 3 gave a limit, no number; the forecaster's own chance of this, stated with the estimate: 15%; middle value at least 1.7-fold (0.25 log units) away from the limit.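

In this assay, compound 3 gives only a limit, > 50000 nM, and not a number. Among the compounds shown here, putting fluoro in place of phenyl on this aromatic carbon, para to a large group, gives an at least 4.5-fold higher number from compound 1 to compound 3 (0.66 log units; beyond the scatter), the first direct reading at this position: in this assay, the phenyl of compound 1 cannot be swapped for fluoro without a clear loss. The step rests on a limit, so only its lower bound is fixed and its full size stays unknown: the limit of > 50000 nM in this assay, at which 1 of the 3 values shown sits.

The compounds shown leave open whether the loss follows the departure of the phenyl ring or the arrival of fluoro, and a bare hydrogen on the same carbon would separate the two. They also leave open how a methoxy group, an amine or a carboxylic acid in that place would stand against the phenyl of compound 1 in this assay.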